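From 2-phenylethenyl to 4-chlorophenyl on a shared core

The compounds below may be only part of what the source reports. "The series", "measured", "known", "first", "only" and "open" are said of these compounds alone.

In a functional assay on A549 cells (Homo sapiens) for inhibition, read by MTT assay, with a stated time of 48 h (a higher number here means a weaker inhibitor, a lower number a stronger inhibitor), compound 1 (`CS(=O)(=O)c1ccc(-c2nc3ccccn3c2Sc2ccccc2)cc1`) gives 23200 nM, compound 2 (`C(=C/c1nc2ccccn2c1Sc1ccccc1)\c1ccccc1`) gives 16300 nM and compound 3 (`Clc1ccc2nc(-c3ccccc3)c(Sc3ccccc3)n2c1`) gives 24400 nM. Compound 2 thus stands within the scatter of both other compounds, so the three cannot be ranked. Compound 4 (`Clc1ccc(-c2nc3ccccn3c2Sc2ccccc2)cc1`) has 4-chlorophenyl in place of 2-phenylethenyl on an aromatic carbon. For the measured compounds named here, no measured pair isolates this change, so the only guide is the narrow spread of the three values. In this assay, the estimated 1.2-fold higher number from compound 2 to compound 4 (0.09 log units; within the scatter) is therefore expected to stay within the scatter, with no clear direction. For compound 4 the estimated value is 20000 nM, with an expected range of 10000 nM to 40000 nM.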

Compound 4, half-maximal inhibitory concentration: 22000 nM
Compound 4: middle estimate off by 1.1-fold (0.04 log units), on the low side, and the stated range covers the measured number.
By their numbers in this assay, from the lowest: compounds 2, 4, 1 and 3 (each within the scatter of the next).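

In this assay, 4-chlorophenyl in place of 2-phenylethenyl gives a 1.3-fold higher number from compound 2 to compound 4 (0.13 log units; within the scatter), so these two groups are not separated at this position. Chloro in place of methylsulfonyl on an aromatic carbon gives a 1.1-fold lower number from compound 1 to compound 4 (0.02 log units; within the scatter), so these two substituents are not separated either. No evidence bears on either step. In all four compounds, the group at this position holds a six-membered aromatic ring of carbon only. From the compounds shown here alone, whether an amine or a carboxylic acid there would give a number beyond the scatter remains open.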